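A Second Methyl on the Benzoxazole Arm

A few compounds are considered here, and "the series" means these few. Any claim that something is new, unique, unknown or untested is made for them only; others in the source may bear on it.

Among the measured compounds shown here, compound 1 `O=C(O)c1csc(SCCN2C(=O)CC[C@@H]2/C=C/[C@@H](O)Cc2cccc(-c3ccc(Cl)cc3)c2)n1` is one of two compounds measured so far in an assay on CHO cells for displacement of a labelled ligand from prostaglandin E2 receptor EP3 subtype (Mus musculus), read by scintillation counting, with a stated time of 60 min; a higher number here means a weaker inhibitor, a lower number a stronger inhibitor. In this assay compound 1 gives only a limit, > 10000 nM. Compound 2 `Cc1cccc2oc(-c3cccc(C[C@H](O)/C=C/[C@H]4CCC(=O)N4CCSc4nc(C(=O)O)cs4)c3)nc12` carries a 4-methyl-1,3-benzoxazol-2-yl in place of the 4-chlorophenyl of compound 1 on an aromatic carbon. In this assay compound 2 likewise gives only a limit, > 10000 nM. The step that the two limits leave unreadable from compound 1 to compound 2 cannot therefore be read; the reason is the limit of > 10000 nM in this assay, at which 2 of the 2 values shown sit. Compound 2 thus stands at the limit, with no number beneath it.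

Compound 3 `Cc1cc(C)c2oc(-c3cccc(C[C@H](O)/C=C/[C@H]4CCC(=O)N4CCSc4nc(C(=O)O)cs4)c3)nc2c1` differs from compound 2 in one place: 5,7-dimethyl-1,3-benzoxazol-2-yl in place of 4-methyl-1,3-benzoxazol-2-yl on an aromatic carbon. For the measured compounds named here, the only measured step, a step that the two limits leave unreadable from compound 1 to compound 2, does not bear on this change in a readable way, and it is a larger exchange than a single added methyl. Nothing in the measured pair points to a gain that would carry compound 3 below the limit. It is therefore expected that compound 3 also returns a limit in this assay, and the expected step that the limit leaves unreadable from compound 2 to compound 3 is none beyond the scatter. The estimate for compound 3 in this assay is 15000 nM, with a range from 5000 nM to 50000 nM.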

Compound 3, inhibition constant: > 10000 nM
Compound 3: no number, only a limit; the forecaster's own chance of this, stated with the estimate: 90%; the middle value lies beyond the limit too.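

In this assay compound 3 gives > 10000 nM, again a limit and not a number. Neither the step from compound 2 to compound 3 nor the step from compound 1 to compound 3 can be read, and the reason is this: the limit of > 10000 nM in this assay, at which 3 of the 3 values shown sit. The compounds shown leave open whether the 4-chlorophenyl, 4-methyl-1,3-benzoxazol-2-yl and 5,7-dimethyl-1,3-benzoxazol-2-yl groups differ at all in this assay.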